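Swapping 4-cyanophenyl for 2-fluorophenyl on a ring amine

The compounds below may be only part of what the source reports. "The series", "measured", "known", "first", "only" and "open" are said of these compounds alone.

Measured so far in a functional assay on FaDu cells (Homo sapiens) for inhibition, read by sulforhodamine B assay (on this read-out higher numbers stand for weaker inhibition and lower numbers for stronger inhibition), and known only as limits
Compound 1 (`COC(=O)CC/C(C)=C/Cc1c(OC)c(C)c2c(c1OCC#CCN1CCN(c3ccc(C#N)cc3)CC1)C(=O)OC2`) gives > 50000 nM as a limit
Compound 2 (`COC(=O)CC/C(C)=C/Cc1c(OC)c(C)c2c(c1OCC#CCN1CCN(C(c3ccc(F)cc3)c3ccc(F)cc3)CC1)C(=O)OC2`) gives > 50000 nM as a limit

Going by the values given here, neither compound has a numerical value in this assay and no step between them can be read. Both sit at the same limit, the limit of > 50000 nM in this assay, at which 2 of the 2 values shown sit, and compound 1 therefore stands at the limit of the numbers shown, not at a measured point. Compound 3 (`COC(=O)CC/C(C)=C/Cc1c(OC)c(C)c2c(c1OCC#CCN1CCN(c3ccccc3F)CC1)C(=O)OC2`) has not yet been measured. It keeps the core of compound 1 and carries 2-fluorophenyl in place of 4-cyanophenyl on an amine nitrogen in a ring. The counted difference is 2-fluorophenyl in place of 4-cyanophenyl on an amine nitrogen in a ring and nothing else changes.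

Among the compounds with values here, no measured step shows what this kind of exchange does. In this assay no step beyond the scatter is expected, or only a small one toward stronger inhibition. This expectation rests on compound 1, which gives > 50000 nM as a limit. The estimate means an at least 1.2-fold lower number from compound 1 to compound 3 (0.09 log units; that floor lies within the scatter) and this expected move is rough, as its starting point is not a number. For compound 3 the expected value is 40000 nM with an estimated range from 15000 nM to 80000 nM and a value that is only a limit is also expected to be quite likely.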

Compound 3, half-maximal inhibitory concentration: > 50000 nM
Compound 3: no number, only a limit (the forecaster's own chance of this, stated with the estimate: 60%); at least 1.2-fold (0.09 log units) between middle value and limit.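

In this assay compound 3 gives > 50000 nM, which is a limit and not a number. Going by these compounds alone, compound 1 also stands only at a limit, so no step between compound 1 and compound 3 can be read: the limit of > 50000 nM in this assay, at which 3 of the 3 values shown sit. The compounds shown leave open whether 2-fluorophenyl in place of 4-cyanophenyl on an amine nitrogen in a ring changes inhibition at all.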